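A few compounds are considered here, and "the series" means these few. Any claim that something is new, unique, unknown or untested is made for them only; others in the source may bear on it.

Compound 1, `CC[C@H](C)C(=O)O[C@H]1C[C@H](O)C=C2C=C[C@H](C)[C@H](CCC(O)C[C@H](O)CC(=O)O)[C@]21C`, gives 5 nM in an assay on microsomes from liver for inhibition of 3-hydroxy-3-methylglutaryl-coenzyme A reductase (Rattus norvegicus); a lower number here means a stronger inhibitor, a higher number a weaker inhibitor.
Compound 2, `O=C(O)C[C@H](O)C[C@H](O)CCn1c(C(F)(F)F)nc(-c2ccc(F)cc2)c1-c1cccc(Cl)c1`, gives 41 nM in this assay.

Of these two numbers compound 2 has the higher one, so it is the weaker inhibitor of the pair, and its gap to compound 1 lies beyond the scatter of repeated measurements. For the measured compounds named here, compound 1 and compound 2 share little beyond the acid-bearing dihydroxy chain, so no single structural step connects them, and their two values say only that the shared core of compound 2 has so far reached a weaker level.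

Compound 3, `Cc1cc(C)cc(-c2c(-c3ccc(F)cc3)nc(C(F)(F)F)n2CC[C@@H](O)C[C@@H](O)CC(=O)O)c1`, is not yet measured. It differs from compound 2 in one place: 3,5-dimethylphenyl in place of 3-chlorophenyl on an aromatic carbon. The change keeps one six-membered aromatic ring of carbon only in the same place, with no hydrogen-bond donor or acceptor lost or gained. Going by the values given here, with no measured step of this kind to lean on, the expected movement is small and in neither direction beyond the scatter.

Compound 3 is expected to give about 30 nM in this assay, within a range from 10 nM to 100 nM.

The expected step of a 1.4-fold lower number from compound 2 to compound 3 (0.14 log units; within the scatter) is estimated to stay within the scatter.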

Compound 3, half-maximal inhibitory concentration: 38 nM
Beside the measured number, compound 3's estimate is 1.3-fold (0.10 log units) below it, within the range that was stated.
By their numbers in this assay, from the lowest: compound 1; then compounds 3 and 2 (each within the scatter of the next).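

For the compounds shown here, this is the first measured step at this position, the aromatic carbon of the five-membered ring next to the ring nitrogen, and in this assay putting 3,5-dimethylphenyl in place of 3-chlorophenyl gives a 1.1-fold lower number from compound 2 to compound 3 (0.03 log units; within the scatter). The position therefore takes either group at the same level in this assay, so the chlorine of 3-chlorophenyl is not required for that level when 3,5-dimethylphenyl stands in its place. Nothing available explains why these two groups match.

Both groups are six-membered aromatic rings of carbon only with no hydrogen-bond donors or acceptors, so these compounds do not show how this position responds to a phenyl ring carrying an amine or a carboxylic acid, or to a saturated ring such as cyclohexyl. As far as these compounds go, it also remains open whether the same match between 3,5-dimethylphenyl and 3-chlorophenyl would hold if the neighbouring 4-fluorophenyl group or the trifluoromethyl group were replaced, for example by a plain phenyl or a methyl group.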